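Swapping the Phenyl Substituent: Estimating Compound 4

A few compounds are considered here, and "the series" means these few. Any claim that something is new, unique, unknown or untested is made for them only; others in the source may bear on it.

Compound 1 `c1ccc(-c2cn3ccnc3c(-c3ccc4ncn(C5CCCCC5)c4c3)n2)cc1`: 45.3%
Compound 2 `CC(=O)c1ccc(-c2cn3ccnc3c(-c3ccc4ncn(C5CCCCC5)c4c3)n2)cc1`: 8.6%
Compound 3 `Brc1ccc(-c2cn3ccnc3c(-c3ccc4ncn(C5CCCCC5)c4c3)n2)cc1`: 8.38%

All three compounds share one core and differ only in the group on the phenyl ring. In a functional assay on NCI-H23 cells (Homo sapiens) for inhibition, read by sulforhodamine B assay, with a stated time of 48 h, tested at 10 uM (a higher number here means more inhibition at the concentration tested (going by the name of the read-out), a lower number less inhibition), compound 1 gives 45.3%, compound 2 gives 8.6%, and compound 3 gives 8.38%. Compound 3 has the lowest of the three numbers, but a number 0.2 percentage points lower from compound 2 to compound 3 (within the scatter) lies within the scatter, so compound 2 and compound 3 cannot be told apart; against compound 1 the gap is clear, a number 36.9 percentage points lower from compound 1 to compound 3 (beyond the scatter).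

Compound 4 `Fc1ccccc1-c1cn2ccnc2c(-c2ccc3ncn(C4CCCCC4)c3c2)n1` differs from compound 3 by 2-fluorophenyl in place of 4-bromophenyl on an aromatic carbon. Among the measured compounds shown here, two measured steps bear on this: a number 36.7 percentage points lower from compound 1 to compound 2 (beyond the scatter) and a number 36.9 percentage points lower from compound 1 to compound 3 (beyond the scatter), both large drops when a group was added to the otherwise bare phenyl ring. For the measured compounds named here, compound 4 keeps a substituted phenyl ring but changes both the substituent and its place on the ring, and no measured pair shows such a change. The expectation is therefore uncertain: the number could stay near compound 3 or recover part way toward compound 1. Compound 4 is estimated at 25% in this assay, within 5% to 50%, which means an expected step of a number 16.6 percentage points higher from compound 3 to compound 4 (beyond the scatter).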

Compound 4, a percentage reported as inhibition, at one concentration (the size of the read-out at that concentration, not a potency): 4.16%
Beside the measured number, compound 4's estimate is 20.8 percentage points above it; measured number outside the range, below it.
By their numbers in this assay, from the lowest: compounds 4, 3 and 2 (each within the scatter of the next); then compound 1.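

A fluoro group on the phenyl ring costs as much as the larger groups did: in this assay, the 2-fluorophenyl compound shows a large loss (a number 41.1 percentage points lower from compound 1 to compound 4 (beyond the scatter)), so the drop seen with the acetyl and bromo groups also appears with a different group in a different ring place. Changing the group and its place together recovers nothing measurable, since the new compound cannot be told apart from either of the other two substituted compounds (a number 4.2 percentage points lower from compound 3 to compound 4 (within the scatter); a number 4.4 percentage points lower from compound 2 to compound 4 (within the scatter)), and among these four compounds only the bare phenyl ring of compound 1 stands clear of the rest. Nothing available here explains why each of these three groups lowers the number.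

Compound 4 changes the group and its place at once, so 4-fluorophenyl would be needed to show whether the place on the ring matters by itself. As far as these compounds go, whether any group on this phenyl ring can match or exceed compound 1 also stays open, for instance an amine, a hydroxyl or a carboxylic acid.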